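Aryl swap on the saturated ring carbon of compound 3

The compounds below may be only part of what the source reports. "The series", "measured", "known", "first", "only" and "open" are said of these compounds alone.

Compound 1 `CCOC(=O)/C=C1/SC(N2N=C(c3cc4ccccc4o3)CC2c2ccc(F)cc2)=NC1=O` gives 0.93 ug/mL in a functional assay on A549 cells (Homo sapiens) for antiproliferative activity, read by MTT assay, with a stated time of 96 h; on this read-out lower numbers stand for stronger inhibition and higher numbers for weaker inhibition. Compound 2 `CCOC(=O)/C=C1/SC(N2N=C(c3cc4ccccc4o3)CC2c2cccc(Br)c2)=NC1=O` reaches only the assay limit > 5 ug/mL in this assay; the step of an at least 5.3-fold higher number from compound 1 to compound 2 (0.73 log units; beyond the scatter) is bounded by the limit of > 5 ug/mL in this assay, at which 1 of the 3 values shown sits. Compound 3 `COC(=O)/C=C1/SC(N2N=C(c3cc4ccccc4o3)CC2c2ccc(F)cc2)=NC1=O` gives 0.808 ug/mL in this assay, the lowest of the two numbers shown, with compound 1 nearest; the step of a 1.2-fold lower number from compound 1 to compound 3 (0.06 log units; within the scatter) sits within the scatter. Compound 4 `COC(=O)/C=C1/SC(N2N=C(c3cc4ccccc4o3)CC2c2ccc(OC)c(OC)c2)=NC1=O` differs from compound 3 by 3,4-dimethoxyphenyl in place of 4-fluorophenyl on a saturated ring carbon. Among the measured compounds shown here, the one measured change at this position, an at least 5.3-fold higher number from compound 1 to compound 2 (0.73 log units; beyond the scatter), raised the number beyond the scatter, so a move upward is expected, though its size is uncertain. Compound 4 is estimated at 2.5 ug/mL in this assay, range 0.8 ug/mL to 6 ug/mL, a step of a 3.1-fold higher number from compound 3 to compound 4 (0.49 log units; beyond the scatter) that is expected.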

Compound 4, half-maximal inhibitory concentration: 0.967 ug/mL
Estimate against measurement, compound 4: 2.6-fold (0.41 log units) above, and the stated range covers the measured number.
By their numbers in this assay, from the lowest: compounds 3, 1 and 4 (each within the scatter of the next). At a limit, above all of these: compound 2.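

In this assay, the step of a 1.2-fold higher number from compound 3 to compound 4 (0.08 log units; within the scatter) shows that a change at this saturated ring carbon need not move the number: 3,4-dimethoxyphenyl, with its 2 hydrogen-bond acceptors, stands level with 4-fluorophenyl. The earlier change here, an at least 5.3-fold higher number from compound 1 to compound 2 (0.73 log units; beyond the scatter), therefore does not describe every aryl swap at this position. Compound 2 is held at a limit: the limit of > 5 ug/mL in this assay, at which 1 of the 4 values shown sits.

Still open, going by these compounds, is whether 3-bromophenyl gives a similar step on the core of compound 3. Also open, on these data alone, is how an amine or a carboxylic acid on the phenyl ring would read.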